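Cytotoxicity of a carbamoyl analogue in the oxazolidinone series

This account rests on a few compounds, and the source may have more. Where it says the series, first, only, none or still open, it means among the compounds named here.

Compound 2 `CN(C)S(=O)(=O)NC[C@H]1CN(c2ccc(-n3cc(-c4ccccn4)cn3)c(F)c2)C(=O)O1` gives 249 ug/mL in an ADME assay on HEK293-A cells (Homo sapiens) for cytotoxicity, read by MTT assay, with a stated time of 48 h (a lower number here means a stronger inhibitor, a higher number a weaker inhibitor), and compound 1 `COC(=O)CC1CCN(C[C@H]2CN(c3ccc(-n4cc(-c5ccccn5)cn4)c(F)c3)C(=O)O2)CC1` gives 224 ug/mL; the two stand within the scatter of each other. Compound 3 `NC(=O)[C@H]1CN(c2ccc(-n3cc(-c4ccccn4)cn3)c(F)c2)C(=O)O1` carries carbamoyl in place of ((dimethylsulfamoyl)amino)methyl on a saturated ring carbon. Among the measured compounds shown here, the one step that bears on this, a 1.1-fold higher number from compound 1 to compound 2 (0.05 log units; within the scatter), also changed the group at this end of the core and moved nothing beyond the scatter. For compound 3 the step of a 1.1-fold lower number from compound 2 to compound 3 (0.03 log units; within the scatter) is therefore expected to stay within the scatter, in no particular direction. Compound 3 is estimated at 230 ug/mL, with a range from 110 ug/mL to 480 ug/mL.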

Compound 3, half-maximal inhibitory concentration: 152 ug/mL
Compound 3: middle estimate off by 1.5-fold (0.18 log units), on the high side; measured number inside the range.
By their numbers in this assay, from the lowest: compounds 3, 1 and 2 (each within the scatter of the next).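

Shrinking the group on this saturated ring carbon to carbamoyl, with 3 heavy atoms against 8 in ((dimethylsulfamoyl)amino)methyl, gives a 1.6-fold lower number from compound 2 to compound 3 (0.21 log units; within the scatter) in this assay. Among the compounds shown here, the comparison with the larger piperidine-bearing group gives a 1.5-fold lower number from compound 1 to compound 3 (0.17 log units; within the scatter), so across these three very different groups, no step at this position leaves the scatter. No supporting measurement bears on this result. Going by these compounds, it remains open whether a carboxylic acid or a primary amine on this ring carbon would stay within the scatter, or whether any group here would move the number beyond it.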